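Swapping Chlorine for Fluorine on an Aromatic Ring

This account rests on a few compounds, and the source may have more. Where it says the series, first, only, none or still open, it means among the compounds named here.

Of the compounds shown here, three built on one shared core have been measured in a functional assay on the whole organism for inhibition, with Rattus norvegicus as the target, with a stated time of 1 h; a lower number here means that less compound is needed, a higher number that more compound is needed for the effect. Compound 1 `CC1(C)OC(/C=C/c2cccnc2)=CC1=O` gives 9 mg/kg. Compound 3 `CC1(C)OC(/C=C/c2ccccn2)=CC1=O` gives 10 mg/kg. Compound 2 `CC1(C)OC(/C=C/c2ccc(Cl)cc2)=CC1=O` gives 10.3 mg/kg, which is the highest of the three numbers, yet its gaps to compound 3 and to compound 1 both lie within the scatter of repeated measurements, so the three results cannot be told apart from one another. The ring attached to the core differs among them, and none of these differences shows up in the numbers.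

Compound 4 `CC1(C)OC(/C=C/c2ccc(F)cc2)=CC1=O` has not yet been measured. It differs from compound 2 in one place: fluoro in place of chloro on an aromatic carbon. The rest of the structure, the core and the double bond linking it to the aromatic ring, is unchanged.

Since the three measured compounds cluster tightly despite carrying different rings, and since the change here is a single halogen exchange on an aromatic carbon, the step from compound 2 to compound 4 is expected to stay within the scatter, as a 1.0-fold lower number from compound 2 to compound 4 (0.01 log units; within the scatter). Compound 4 is therefore expected to give about 10 mg/kg in this assay, with a range from 5 mg/kg to 20 mg/kg.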

Compound 4, dose for half-maximal effect: 11 mg/kg
Estimate against measurement, compound 4: 1.1-fold (0.04 log units) below; low and high end bracket the measured number.
By their numbers in this assay, from the lowest: compounds 1, 3, 2 and 4 (each within the scatter of the next).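

In this assay the exchange of chloro for fluoro on an aromatic carbon, para to a large group, gives a 1.1-fold higher number from compound 2 to compound 4 (0.03 log units; within the scatter) and so leaves the number unchanged within the usual scatter. The earlier compounds shown here differ from one another in their rings and offered no single-place comparison, whereas this pair isolates one atom at one position and shows that these two halogens cannot be told apart here. Nothing measured in this set offers an explanation for this result.

The compounds shown pair only chloro and fluoro at this position, so it remains open whether the number would stay in the same range with plain hydrogen there, or with a group of another kind, such as an amine, a carboxylic acid or a longer alkyl chain. Also open, on these data alone, is whether the same halogen exchange would give a similar outcome at another place on the ring or with a changed shared core.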